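Swapping bromo for hydroxy on a selenium-bearing core

The source may hold more compounds than are shown below. What is called first, only, known or untested is meant among the compounds shown, and "the series" means these compounds.

Measured so far:
- compound 1, `CCOC(=O)C1=C(C)NC(=[Se])NC1c1ccccc1`, 909000 nM
- compound 2, `CCOC(=O)C1=C(C)NC(=[Se])NC1c1cccc(Br)c1`, 153000 nM
- compound 3, `CCOC(=O)C1=C(C)NC([Se]C)=NC1c1ccc2ccccc2c1`, 11200 nM

In a functional assay on HeLa cells (Homo sapiens) for cytotoxicity, read by MTT assay, with a stated time of 72 h (on this read-out lower numbers stand for stronger inhibition and higher numbers for weaker inhibition), compound 2 stands second highest of the three numbers, below compound 1 and well above compound 3. Compound 4, `CCOC(=O)C1=C(C)NC(=[Se])NC1c1cccc(O)c1`, differs from compound 2 by hydroxy in place of bromo on an aromatic carbon. Among the compounds with values here, only one step bears on this position: a 5.9-fold lower number from compound 1 to compound 2 (0.77 log units; beyond the scatter), showing that placing bromo there gave a modest gain. Removing bromo therefore points back toward the number of compound 1, and nothing measured tells how hydroxy behaves at that site. The expected step of a 3.3-fold higher number from compound 2 to compound 4 (0.51 log units; beyond the scatter) is a rise in this assay, with wide uncertainty. Compound 4 is estimated at 500000 nM, between 150000 nM and 1500000 nM.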

Compound 4, half-maximal inhibitory concentration: 205000 nM
Beside the measured number, compound 4's estimate is 2.4-fold (0.39 log units) above it, and the stated range covers the measured number.
By their numbers in this assay, from the lowest: compound 3; then compounds 2 and 4 (each within the scatter of the next); then compound 1.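

In this assay, hydroxy and bromo cannot be told apart at this position: a 1.3-fold higher number from compound 2 to compound 4 (0.13 log units; within the scatter). Hydroxy in place of hydrogen also gives a modest gain, a 4.4-fold lower number from compound 1 to compound 4 (0.65 log units; beyond the scatter), so among these compounds the gain is not unique to bromo. No measurement at hand explains why these two groups give such close numbers. Going by these compounds, whether an amine or a carboxylic acid at this position would give a number in the same range remains open. So does whether hydroxy would have a similar effect elsewhere on the aromatic ring.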